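Swapping the aryl ring on a thiazolidinone core

A few compounds are considered here, and "the series" means these few. Any claim that something is new, unique, unknown or untested is made for them only; others in the source may bear on it.

Measured compounds:
- compound 1, `O=C1CSC(c2cccc(Cl)c2)N1CCN1CCCCC1`: 77%
- compound 2, `O=C1CSC(c2cccc(O)c2)N1CCN1CCCCC1`: 100%
- compound 3, `Cc1ccc(C2SCC(=O)N2CCN2CCCCC2)cc1`: 85%

Three compounds sharing one core were tested in an ADME assay on Vero cells (Chlorocebus sabaeus) for cytotoxicity, read by neutral red uptake, tested at 197 ug/mL; on this read-out higher numbers stand for a weaker effect at the one concentration tested and lower numbers for a stronger effect. Compound 3 stands second highest of the three; its nearest neighbour is compound 1, whose value lies within the scatter of that of compound 3, while compound 2 is the furthest, with a number 15 percentage points lower from compound 2 to compound 3 (beyond the scatter) separating the two. Within the data shown here, the only step beyond the scatter among the measured pairs is a number 23 percentage points higher from compound 1 to compound 2 (beyond the scatter), where hydroxy replaces chloro on an aromatic carbon.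

Compound 4, `O=C1CSC(c2cccc(F)c2)N1CCN1CCCCC1`, has not yet been measured in this assay. It differs from compound 3 as follows: 3-fluorophenyl in place of 4-methylphenyl on a saturated ring carbon. The step that bears most directly on it is a number 8 percentage points higher from compound 1 to compound 3 (within the scatter), which also exchanges a halogen-bearing 3-substituted phenyl for 4-methylphenyl and stayed within the scatter. Compound 4 is therefore expected to sit close to compound 3 and compound 1, with a step of about a number 5 percentage points lower from compound 3 to compound 4 (within the scatter), not beyond the scatter. The estimate for compound 4 in this assay is 80%, with a range from 65% to 100%.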

Compound 4, a percentage reported as activity, at one concentration (the size of the read-out at that concentration, not a potency): 84%
Compound 4: the middle estimate sits 4 percentage points below what was measured; the range from low to high includes it.
By their numbers in this assay, from the lowest: compounds 1, 4 and 3 (each within the scatter of the next); then compound 2.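

In this assay, 3-fluorophenyl in place of 4-methylphenyl on the saturated ring carbon gives a number 1 percentage points lower from compound 3 to compound 4 (within the scatter), and fluoro in place of chloro on an aromatic carbon gives a number 7 percentage points higher from compound 1 to compound 4 (within the scatter), so at this position the fluoro, chloro and methyl aryl groups cannot yet be told apart on this read-out. Among these compounds, the hydroxy compound, by contrast, now stands apart from a third partner, since fluoro in place of hydroxy gives a number 16 percentage points lower from compound 2 to compound 4 (beyond the scatter), which makes compound 2 the one compound of the four separated from all the others, with the highest number and so the weakest effect at the concentration tested. Nothing measured here explains why the hydroxy group differs from the other three substituents.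

As far as these compounds go, it remains open whether an amine or a carboxylic acid on the aromatic ring would group with hydroxy or with the other three, and whether methoxy, which keeps the oxygen but lacks the hydroxy hydrogen, would do the same. From the compounds shown here alone, all four numbers also come from a single concentration, so how these compounds would compare at other concentrations stays unknown.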